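Adding a methoxy group to compound 2

The source may report more compounds than this note shows. Statements on the series, on what has been measured and on what is new or still open speak of the compounds shown alone.

compound 1 `COc1ccc2oc(=O)c(=O)[nH]c2c1`: 15000 nM
compound 2 `COc1ccc2[nH]c(=O)c(=O)oc2c1`: 28000 nM
compound 3 `O=C(O)c1ccc2[nH]c(=O)c(=O)oc2c1`: 16000 nM

These values come from a functional assay with Rattus norvegicus as the target; a higher number here means a weaker inhibitor, a lower number a stronger inhibitor. On these numbers, compound 2 at 28000 nM cannot be told apart from compound 1 or compound 3, since both lie within the usual scatter of it.

Compound 4 `COc1cc2[nH]c(=O)c(=O)oc2cc1OC` differs from compound 2 by one change: methoxy in place of hydrogen on an aromatic carbon, ortho to a methoxy group (methoxy in place of hydrogen on an aromatic carbon).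

For the measured compounds named here, only one measured step offers guidance, and it is a 1.8-fold lower number from compound 2 to compound 3 (0.24 log units; within the scatter). That step puts carboxy in place of methoxy, which is a different change, so it is only a loose guide. Going by the values given here, no measured step shows what adding a methoxy does. Among the compounds with values here, still, the one step available stayed small, so no clear move in either direction is expected in this assay.

The expected step is a 1.1-fold lower number from compound 2 to compound 4 (0.05 log units; within the scatter), which means none beyond the scatter. For compound 4 the estimated value is 25000 nM, with an expected range from 10000 nM to 60000 nM.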

Compound 4, half-maximal inhibitory concentration: 30000 nM
Compound 4: middle estimate off by 1.2-fold (0.08 log units), on the low side; low and high end bracket the measured number.
By their numbers in this assay, from the lowest: compounds 1, 3, 2 and 4 (each within the scatter of the next).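

In this assay a methoxy group placed on this aromatic carbon, ortho to a methoxy group, gives a 1.1-fold higher number from compound 2 to compound 4 (0.03 log units; within the scatter) and so leaves compound 2 and compound 4 indistinguishable. For the compounds shown here, this is the first direct reading of what adding a methoxy group does here, and it shows no effect that can be told from the scatter. The comparison with the other relative gives a 2.0-fold higher number from compound 1 to compound 4 (0.30 log units; within the scatter) and also stays within the scatter, and no further data are available to explain these results.

From the compounds shown here alone, what stays open is whether a different group on this aromatic carbon, such as an amine, a carboxylic acid or a longer chain like butoxy, would give a step beyond the scatter. A single methoxy group cannot show whether this position tolerates every change or only this one.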